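Replacing an aryl cap with cyclohexyl on a piperazine

This account rests on a few compounds, and the source may have more. Where it says the series, first, only, none or still open, it means among the compounds named here.

Compound 1 `O=C(CN1CCN(c2ccc(F)cn2)CC1)Nc1nc2c(o1)CCCC2`: 100 nM
Compound 2 `Cc1ccc(N2CCN(CC(=O)Nc3nc4c(s3)CCCC4)CC2)cc1`: 250 nM

Both compounds were tested in an assay on isolated protein for inhibition of long-chain fatty acid transport protein 1 (Homo sapiens), read by scintillation counting, with a stated time of 20 min; on this read-out lower numbers stand for stronger inhibition and higher numbers for weaker inhibition. Compound 2 shows the higher of the two numbers, and compound 1 stands a step below it, beyond the usual scatter. Compound 3 `O=C(CN1CCN(C2CCCCC2)CC1)Nc1nc2c(s1)CCCC2` has not yet been measured. Compared with compound 2 it carries cyclohexyl in place of 4-methylphenyl on an amine nitrogen in a ring. For the measured compounds named here, no measured pair shows this change, so its effect is open. Compound 3 is expected to show a step of a 1.6-fold higher number from compound 2 to compound 3 (0.20 log units; within the scatter) in this assay, a modest rise that may stay within the scatter. The estimate for compound 3 is 400 nM, with a range from 150 nM to 1200 nM.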

Compound 3, half-maximal inhibitory concentration: > 1000 nM
Compound 3: no number, only a limit; the forecaster's own chance of this, stated with the estimate: 5%; at least 2.5-fold (0.39 log units) between middle value and limit.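

In this assay compound 3 returns a limit and not a number: the limit of > 1000 nM in this assay, at which 1 of the 3 values shown sits. Cyclohexyl in place of 4-methylphenyl on this amine nitrogen in a ring gives an at least 4.0-fold higher number from compound 2 to compound 3 (0.60 log units; beyond the scatter), so for this pair a six-membered non-aromatic ring of carbon does not stand in for the six-membered aromatic ring. The compounds shown leave open whether a plain phenyl, a benzyl or a cyclopentyl on this nitrogen would stay close to compound 2. As far as these compounds go, whether the same change would act alike on the core of compound 1 also remains open.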